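One Step From Ethoxy to Propoxy

The source may report more compounds than this note shows. Statements on the series, on what has been measured and on what is new or still open speak of the compounds shown alone.

Compound 1 `CCCOOC1(OOCCC)CCCCCCCCCCC1` measured at 12000 nM
Compound 2 `CCOOC1(OC)CCCCCCCCCCC1` measured at 26000 nM

Both numbers come from a functional assay on FM3A cells (Mus musculus) for cytotoxicity (on this read-out higher numbers stand for an effect only at larger amounts of compound and lower numbers for an effect already at smaller amounts), and are all that has been measured so far. Compound 2 stands higher with 26000 nM as its value, so it shows its effect only at a larger amount than compound 1 does. That gap lies beyond the usual scatter of repeated measurements. The two compounds differ in more than one place, so their values cannot be tied to any single change.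

Compound 3 `CCCOOC1(OC)CCCCCCCCCCC1` has not been measured yet. It differs from compound 2 by one small edit methyl in place of hydrogen on a saturated chain carbon, two bonds along the chain from an oxygen on an unsaturated carbon that places methyl in place of hydrogen on a saturated chain carbon, which also reads as ethoxy to propoxy. Among the measured compounds shown here, no measured pair shows this change alone. Compound 1 also carries propoxy and gives 12000 nM as its value, which offers a weak hint toward a lower number. In this assay a small move to a lower number is expected, an estimated step of a 1.4-fold lower number from compound 2 to compound 3 (0.14 log units; within the scatter) that would stay within the scatter. The estimate for compound 3 is 19000 nM with an expected range from 9000 nM to 40000 nM as its upper end.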

Compound 3, half-maximal effective concentration: > 37000 nM
Compound 3 ended at the assay's limit (the forecaster's own chance of this, stated with the estimate: 3%); at least 1.9-fold (0.28 log units) between middle value and limit.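

In this assay compound 3 gives > 37000 nM, which is a limit of the assay and not a number. Lengthening ethoxy to propoxy at this position gives an at least 1.4-fold higher number from compound 2 to compound 3 (0.15 log units; that floor lies within the scatter), so this single edit does not bring the effect down to smaller amounts of compound, although the printed floor of the step cannot be told apart from the scatter and its true size stays hidden behind the limit. Among the compounds shown here, the other single-place comparison, methyl in place of propoxy on an oxygen on a saturated carbon, gives an at least 3.0-fold higher number from compound 1 to compound 3 (0.48 log units; beyond the scatter), and this is the first step that clearly exceeds the scatter, so what sits on that oxygen makes a real difference in this assay.

As far as these compounds go, how far compound 3 truly lies past its limit stays open, and so does the size of the ethoxy to propoxy step. The compounds shown also leave open what a longer chain such as butoxy, or an amine at the end of the chain, would do at this same position.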